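Amide to urea on the shared core

A few compounds are considered here, and "the series" means these few. Any claim that something is new, unique, unknown or untested is made for them only; others in the source may bear on it.

Three compounds share one core: compound 1 `O=C(Nc1cccc(-n2cc(-c3ccncc3)c(-c3ccc(Cl)c(O)c3)n2)c1)Nc1ccc(Cl)c(Cl)c1`, compound 2 `COc1cc(-c2nn(-c3cccc(NC(=O)c4ccc(Cl)c(C(F)(F)F)c4)c3)cc2-c2ccncc2)ccc1Cl` and compound 3 `COc1cc(-c2nn(-c3cccc(NC(=O)Nc4cccc(C(F)(F)F)c4)c3)cc2-c2ccncc2)ccc1Cl`, while compound 4 `COc1cc(-c2nn(-c3cccc(NC(=O)Nc4ccc(Cl)c(C(F)(F)F)c4)c3)cc2-c2ccncc2)ccc1Cl` awaits measurement. In a functional assay on Malme-3M cells (Homo sapiens) for inhibition, read by sulforhodamine B assay, with a stated time of 48 h (a lower number here means that less compound is tolerated, a higher number that more compound is tolerated), compound 1 reaches only the limit > 32500 nM. In this assay compound 2 likewise stops at a limit, > 32500 nM, so compound 2 stands among the values shown only as a limit. Compound 3 gives 33900 nM in this assay, and the step that the limit leaves unreadable from compound 2 to compound 3 therefore cannot be sized. Compound 4 differs from compound 2 by (4-chloro-3-(trifluoromethyl)phenyl)amino in place of 4-chloro-3-(trifluoromethyl)phenyl on a carbonyl carbon. Among the compounds with values here, the one measured step bearing on this change is unreadable, and the two limits match (the limit of > 32500 nM in this assay, at which 2 of the 3 values shown sit). No step beyond the scatter is expected in this assay. The expected step is a step that the limit leaves unreadable from compound 2 to compound 4. Compound 4 is estimated at 35000 nM, between 15000 nM and 80000 nM.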

Compound 4, concentration lethal to 50% of the cells: > 32500 nM
Compound 4: no number, only a limit; the forecaster's own chance of this, stated with the estimate: 70%; the middle value does not contradict the limit.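

Compound 4 stops at a limit in this assay, so no step from compound 2 or compound 3 to compound 4 can be read: the limit of > 32500 nM in this assay, at which 3 of the 4 values shown sit.

The compounds shown leave open whether the amino on the carbonyl carbon, or chloro in place of hydrogen on an aromatic carbon, changes the value in this assay at all.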